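The source may report more compounds than this note shows. Statements on the series, on what has been measured and on what is new or still open speak of the compounds shown alone.

Compound 1 `N#Cc1cnc(NCc2cnccc2C(F)(F)F)cc1N[C@H]1C[C@@H](O)C1` is the reference point of this series. For the measured compounds named here, in an ADME assay on S9 fraction from liver (Rattus norvegicus) for metabolic stability, with a stated time of 1 h (a lower number here means that less of the compound is left, a higher number that more of the compound is left), compound 1 gives 70%, the higher of the two numbers measured so far. Compound 2 `N#Cc1cnc(NCc2cnccc2C(F)(F)F)cc1NC[C@H]1C[C@@H](O)C1` gives 44% in this assay, and the step of a number 26 percentage points lower from compound 1 to compound 2 (beyond the scatter) came with (3-hydroxycyclobutyl)methyl in place of 3-hydroxycyclobutyl on a nitrogen on an aromatic ring. Compound 3 `CNC(=O)[C@H]1CC[C@@H](Nc2cc(NCc3cnccc3C(F)(F)F)ncc2C#N)CC1` is the next case: 4-(methylcarbamoyl)cyclohexyl in place of 3-hydroxycyclobutyl on a nitrogen on an aromatic ring. Going by the values given here, the only measured step that bears on it is a number 26 percentage points lower from compound 1 to compound 2 (beyond the scatter), the sole change made at that nitrogen so far, and it went down modestly, beyond the scatter. The change to compound 3 is the larger one by the counted atoms and has no measured partner of its own, so a downward step of similar or somewhat larger size is expected, a number 22 percentage points lower from compound 1 to compound 3 (beyond the scatter). Compound 3 is therefore estimated at 48% in this assay, within 25% to 72%.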

Compound 3, percent of the compound remaining: 53%
Beside the measured number, compound 3's estimate is 5 percentage points below it, within the range that was stated.
By their numbers in this assay, from the lowest: compounds 2 and 3 (each within the scatter of the next); then compound 1.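

At the nitrogen on an aromatic ring, a second replacement of 3-hydroxycyclobutyl, this time by 4-(methylcarbamoyl)cyclohexyl, also lowers the number in this assay, with a number 17 percentage points lower from compound 1 to compound 3 (beyond the scatter) as the step. Both replacements shown therefore stand lower than compound 1, although one keeps the four-membered ring and the hydroxyl while the other brings a six-membered ring and an amide. For the compounds shown here, the two replacements are not separated, with a number 9 percentage points higher from compound 2 to compound 3 (within the scatter) as the only comparison between them. No available evidence bears on the reason for these steps.

The compounds shown leave open how a 3-hydroxycyclobutyl compares at this nitrogen with a plain cyclobutyl or a 4-hydroxycyclohexyl. They also leave open how a carboxylic acid or an amine would compare with the methylcarbamoyl on the cyclohexyl ring.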